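Notes on the benzyl group step toward compound 4

The source may hold more compounds than are shown below. What is called first, only, known or untested is meant among the compounds shown, and "the series" means these compounds.

Measured so far:
compound 1, `C#CCN(CCCCOc1ccc2ccc(=O)oc2c1)Cc1cccc(OC)c1`, 2340 nM
compound 2, `C#CCN(CCCCOc1ccc2ccc(=O)oc2c1)Cc1cccc(F)c1`, 1550 nM
compound 3, `C#CCN(CCCCOc1ccc2ccc(=O)oc2c1)Cc1ccc(C(C)C)cc1`, 3500 nM

All three were run in an assay on isolated protein for inhibition of Amine oxidase [flavin-containing] B (Homo sapiens), read by fluorescence and Amplex Red, with stated times of 15 min and 20 min; a lower number here means a stronger inhibitor, a higher number a weaker inhibitor. Compound 3 carries the highest of the three numbers, though its nearest neighbour is compound 1, at a 1.5-fold higher number from compound 1 to compound 3 (0.17 log units; within the scatter), and only the gap to compound 2, a 2.3-fold higher number from compound 2 to compound 3 (0.35 log units; beyond the scatter), lies beyond the scatter. Compound 1 and compound 2 differ by a 1.5-fold lower number from compound 1 to compound 2 (0.18 log units; within the scatter).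

Compound 4, `C#CCN(CCCCOc1ccc2ccc(=O)oc2c1)Cc1ccc(C)cc1`, is the next compound to be run in this assay. It differs from compound 3 in one place: methyl in place of isopropyl on an aromatic carbon. Read one bond further out, the change is 4-isopropylbenzyl to 4-methylbenzyl.

For the measured compounds named here, none of the measured steps changes the same group: the two steps that reach compound 3 swap the whole benzyl ring rather than trim one group on it, and both are small, one within the scatter and one modest. Going by the values given here, their only bearing is that compound 3 sits at the high end of a narrow spread. Cutting the isopropyl back to methyl is therefore expected to give a modest change at most, and the expected direction is downward, toward the numbers of compound 1 and compound 2. The expected step is a 1.4-fold lower number from compound 3 to compound 4 (0.15 log units; within the scatter). Compound 4 is estimated at 2500 nM, with a range from 1200 nM to 5500 nM.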

Compound 4, half-maximal inhibitory concentration: 1680 nM
Compound 4: the middle estimate sits 1.5-fold (0.17 log units) above what was measured; the range from low to high includes it.
By their numbers in this assay, from the lowest: compounds 2, 4, 1 and 3 (each within the scatter of the next, the first and the last beyond it).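

For the compounds shown here, this is the first step that changes only the group on the benzyl ring while leaving the ring in place: in this assay, methyl in place of isopropyl, three heavy atoms cut to one carbon, gives a modest change beyond the scatter (a 2.1-fold lower number from compound 3 to compound 4 (0.32 log units; beyond the scatter)). The 4-methylbenzyl group cannot be told apart from either the 3-fluorobenzyl group (a 1.1-fold higher number from compound 2 to compound 4 (0.03 log units; within the scatter)) or the 3-methoxybenzyl group (a 1.4-fold lower number from compound 1 to compound 4 (0.14 log units; within the scatter)), so among these compounds the 4-isopropylbenzyl group alone lies beyond the scatter of any neighbour, and even it stays within the scatter of compound 1. Nothing available on these compounds explains the step.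

The compounds shown leave open how the number moves across the groups on either side of this step, such as ethyl or tert-butyl on the same aromatic carbon, or a plain benzyl group with no added group on the ring. They also never hold one group fixed while its place on the ring moves, so the effect of the group and that of its place remain tangled.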